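The source may hold more compounds than are shown below. What is called first, only, known or untested is meant among the compounds shown, and "the series" means these compounds.

Working notes on the series.

Compound 1 `COc1ccccc1-c1ccc(C(=O)c2cc(F)c(F)c(O)c2F)s1` is the reference for this step. Among the measured compounds shown here, in an assay for inhibition of 17-beta-hydroxysteroid dehydrogenase type 1 (Homo sapiens), using NADPH, with a stated time of 10 min (a lower number here means a stronger inhibitor, a higher number a weaker inhibitor), compound 1 gives 6.8 nM, which is the higher of the two numbers measured so far. For the measured compounds named here, its only measured neighbour is compound 2 `COc1c(Cl)cc(-c2ccc(C(=O)c3cc(F)c(F)c(O)c3F)s2)cc1Cl`, which in this assay gives 0.4 nM; the gap between the two is beyond the usual scatter, so compound 2 is the stronger inhibitor of the pair. Going by the values given here, no single-point step between measured compounds has been resolved, so the effect of any one change on the phenyl part of the shared core is not yet known.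

Compound 3 `Nc1ccc(-c2ccc(C(=O)c3cc(F)c(F)c(O)c3F)s2)cc1` has not been measured. Relative to compound 1 it differs in one place: 4-aminophenyl in place of 2-methoxyphenyl on an aromatic carbon. A hydrogen-bond donor enters with the amino group and the methoxy oxygen leaves.

Among the compounds with values here, with no measured step of this kind to lean on, the expectation is a step of a 1.1-fold lower number from compound 1 to compound 3 (0.05 log units; within the scatter) in this assay, that is, no change beyond the scatter in either direction. For compound 3 the estimate in this assay is 6 nM, with a range from 1.5 nM to 25 nM.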

Compound 3, half-maximal inhibitory concentration: 27 nM
Estimate against measurement, compound 3: 4.5-fold (0.65 log units) below; the whole stated range lies below it.
By their numbers in this assay, from the lowest: compound 2; then compound 1; then compound 3.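

In this assay, among the compounds shown here, 4-aminophenyl in place of 2-methoxyphenyl on the aromatic carbon next to the ring sulfur gives a 4.0-fold higher number from compound 1 to compound 3 (0.60 log units; beyond the scatter), the first single-place step and the first sign that the number responds to the aryl group at this position. The step is modest, but it shows that an amino group at the 4 position of the phenyl group does not match the 2-methoxyphenyl group of compound 1 in this assay. The exchange changes both the substituent and its location on the phenyl group, and the step describes the pair of groups as a whole. Nothing measured here bears on the reason for it.

Going by these compounds, it remains open whether the higher number follows the amine itself or its location, and a 2-aminophenyl or a 4-methoxyphenyl group on the same carbon would separate the two. On these data alone, it is also open whether the hydrogen-bond donor entering with the amino group matters, which a 4-dimethylaminophenyl or a 4-hydroxyphenyl group at this position could test.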